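A few compounds are considered here, and "the series" means these few. Any claim that something is new, unique, unknown or untested is made for them only; others in the source may bear on it.

Measured compounds:
compound 1 `CCN1CCN(c2cc(C)c3cc(NC(=O)c4ccc(Cl)cc4)ccc3n2)CC1` — in a functional assay on SK-BR-3 cells (Homo sapiens) for antiproliferative activity, read by MTT assay, with a stated time of 72 h (on this read-out higher numbers stand for weaker inhibition and lower numbers for stronger inhibition), compound 1 gives 3020 nM
compound 2 `CCN1CCN(c2cc(C)c3cc(NC(=O)c4cccc(F)c4)ccc3n2)CC1` — in this assay compound 2 gives 24900 nM
compound 3 `CCN1CCN(c2cc(C)c3cc(NC(=O)c4cccnc4)ccc3n2)CC1` — in this assay compound 3 gives 10600 nM

Compound 3 stands second highest of the three numbers: a 3.5-fold higher number from compound 1 to compound 3 (0.55 log units; beyond the scatter), while a 2.3-fold lower number from compound 2 to compound 3 (0.37 log units; beyond the scatter). Among the measured compounds shown here, the series so far only varies the aryl group on the carbonyl carbon, and all three steps lie beyond the scatter but remain modest: an 8.2-fold higher number from compound 1 to compound 2 (0.92 log units; beyond the scatter).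

Compound 4 `CCN1CCN(c2cc(C)c3cc(NC(=O)c4ccccc4OC)ccc3n2)CC1` continues this variation: 2-methoxyphenyl in place of pyridin-3-yl on a carbonyl carbon. For the measured compounds named here, no measured step introduces a methoxy group or an ortho-type pattern, so the three aryl swaps are the only guide; they show that exchanging the aryl group moves the number by modest amounts in either direction, with no clear direction for this particular exchange. The expected step is a 1.1-fold higher number from compound 3 to compound 4 (0.05 log units; within the scatter), i.e. a number near that of compound 3, with a wide band. Compound 4 is estimated at 12000 nM, within 4000 nM to 40000 nM.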

Compound 4, half-maximal inhibitory concentration: 15700 nM
For compound 4 the middle estimate is 1.3-fold (0.12 log units) below the measured one; the measured number falls inside the stated range.
By their numbers in this assay, from the lowest: compound 1; then compounds 3, 4 and 2 (each within the scatter of the next, the first and the last beyond it).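

In this assay the 2-methoxyphenyl group on the carbonyl carbon cannot be told apart from either of its nearest neighbours, with a 1.5-fold higher number from compound 3 to compound 4 (0.17 log units; within the scatter) and a 1.6-fold lower number from compound 2 to compound 4 (0.20 log units; within the scatter) both within the scatter, even though compounds 2 and 3 lie beyond the scatter of each other. Only the exchange for 4-chlorophenyl gives a step beyond the scatter, with a 5.2-fold higher number from compound 1 to compound 4 (0.72 log units; beyond the scatter), so compound 1 now holds the lowest number against all three other aryl groups, whether these carry fluorine, a methoxy group or a ring nitrogen. No measurement available here accounts for the standing of 4-chlorophenyl.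

Going by these compounds, it remains open whether the chlorine or its place on the ring sets compound 1 apart, which 3-chlorophenyl and 4-fluorophenyl would separate. Also open, on these data alone, is how this position responds to an aryl group carrying an amine or a carboxylic acid, or to a non-aromatic group such as a longer alkyl chain.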